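The source may hold more compounds than are shown below. What is called first, only, known or untested is meant among the compounds shown, and "the series" means these compounds.

Measured so far:
- Compound 1 `OB1OCc2ccc(-n3cc(Sc4cccc(Cl)c4)c4ccccc43)cc21`: in an ADME assay on L929 cells (Mus musculus) for cytotoxicity, read by resazurin assay, with a stated time of 72 h (on this read-out higher numbers stand for weaker inhibition and lower numbers for stronger inhibition), compound 1 gives > 10 ug/mL, which is a limit of the assay and not a number.
- Compound 2 `OB1OCc2ccc(-n3cc(Sc4ccccc4O)c4ccccc43)cc21`: in this assay compound 2 gives > 10 ug/mL, again a limit and not a number.

Compound 2 thus stands at the limit of > 10 ug/mL in this assay, at which 2 of the 2 values shown sit. Compound 3 `OB1OCc2ccc(-n3cc(Sc4ccc5ccccc5c4)c4ccccc43)cc21` differs from compound 2 by naphthalen-2-yl in place of 2-hydroxyphenyl on a sulfur. For the measured compounds named here, the only measured step, a step that the two limits leave unreadable from compound 1 to compound 2, gives no readable size, so no size for this change can be taken from it. The step expected in this assay is therefore a step that the limit leaves unreadable from compound 2 to compound 3, none beyond the scatter. Compound 3 is estimated at 15 ug/mL, in a range from 5 ug/mL to 50 ug/mL.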

Compound 3, half-maximal inhibitory concentration: > 10 ug/mL
Compound 3 gave a limit, no number (the forecaster's own chance of this, stated with the estimate: 75%); the middle value does not contradict the limit.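

Compound 1, compound 2 and compound 3 each give a limit and not a number in this assay, so no step among them can be read: the limit of > 10 ug/mL in this assay, at which 3 of the 3 values shown sit.

On these data alone, whether the groups on the sulfur change cytotoxicity at all, and by how much, stays open.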